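Amino to chloro: what compound 3 may show

The compounds below may be only part of what the source reports. "The series", "measured", "known", "first", "only" and "open" are said of these compounds alone.

Measured so far in a functional assay on KB cells (Homo sapiens) for inhibition; on this read-out lower numbers stand for stronger inhibition and higher numbers for weaker inhibition
- compound 1 `CC(C)(C)c1ccc(Cn2c(N)nc3cc(Cl)c(Cl)cc32)cc1` gives 50000 nM
- compound 2 `Nc1nc2cc(Cl)c(Cl)cc2n1Cc1ccc([N+](=O)[O-])cc1` gives 35000 nM

These two values lie within the usual scatter of each other, so compound 1 cannot be ranked against compound 2. Compound 3 `CC(C)(C)c1ccc(Cn2c(Cl)nc3cc(Cl)c(Cl)cc32)cc1` has not been measured. It keeps the core of compound 1 and its tert-butyl group. The change chloro in place of amino on an aromatic carbon puts chloro in place of amino on an aromatic carbon, between two ring nitrogen atoms.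

Going by the values given here, only one measured step exists (a 1.4-fold lower number from compound 1 to compound 2 (0.15 log units; within the scatter)) and it bears on this change only loosely. It swaps the tert-butyl group at a different place and leaves the amino untouched. No measurement here shows what happens when the amino group leaves, so the uncertainty is wide. With no evidence for a direction, no step beyond the scatter is expected in this assay for this change. An estimated 1.3-fold lower number from compound 1 to compound 3 (0.10 log units; within the scatter) is what this reasoning gives. Compound 3 is estimated at 40000 nM (expected range 10000 nM to 100000 nM).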

Compound 3, half-maximal inhibitory concentration: > 100000 nM
Compound 3 was reported as a limit; the forecaster's own chance of this, stated with the estimate: 25%; middle value at least 2.5-fold (0.39 log units) from the limit.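

In this assay compound 3 gives > 100000 nM, which is a limit of the assay and not a number. Going by these compounds alone, the step reads an at least 2.0-fold higher number from compound 1 to compound 3 (0.30 log units; that floor lies within the scatter), so this is the first measurement at this position, between two ring nitrogen atoms, and putting chloro in place of amino gave no sign of stronger inhibition, although the floor of the step on its own cannot be told apart from the scatter. The true size of the step therefore stays unknown, and the result can be read only as a floor: the limit of > 100000 nM in this assay, at which 1 of the 3 values shown sits.

The compounds shown leave open whether other groups at this position, such as methyl, hydroxyl or methylamino, would give a value that can be read as a number rather than a limit, which would help show whether anything about the amino group itself matters here. They also leave open whether the same change from amino to chloro would give a similar result with the nitro group of compound 2 in place of the tert-butyl group.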